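The source may hold more compounds than are shown below. What is called first, only, known or untested is meant among the compounds shown, and "the series" means these compounds.

Of the compounds shown here, two built on a shared core have been tested in an ADME assay on HepG2 cells (Homo sapiens) for cytotoxicity, read by MTT assay, with a stated time of 48 h; a higher number here means a weaker inhibitor, a lower number a stronger inhibitor. Compound 1 `CCN(CC)CCN/C(=N\c1ccnc2cc(Cl)ccc12)C(C)C` gives 12.7 ug/mL in this assay, and compound 2 `CN(C)CCCN/C(=N\c1ccnc2cc(Cl)ccc12)c1ccc(Cl)cc1` gives 1.93 ug/mL. Of these two numbers, compound 2 holds the lower one, and its gap to compound 1 lies beyond the usual scatter, so compound 2 is the stronger inhibitor of the pair. The next compound, compound 3 `CN(C)CCCN/C(=N\c1ccnc2cc(Cl)ccc12)c1ccccc1`, keeps everything in compound 2 except one point: hydrogen in place of chloro on an aromatic carbon. For the measured compounds named here, no measured pair in this set shows what such a change does to the number, so the expectation rests on the value of compound 2 alone. The expected step, a 1.7-fold higher number from compound 2 to compound 3 (0.22 log units; within the scatter), is small, probably within the scatter, leaning if anything toward a slightly higher number. Compound 3 is therefore estimated at 3.2 ug/mL, with a likely range from 1.3 ug/mL to 8 ug/mL.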

Compound 3, half-maximal inhibitory concentration: 5.13 ug/mL
The estimate for compound 3 lay 1.6-fold (0.20 log units) below the measured number; measured number inside the range.
By their numbers in this assay, from the lowest: compound 2; then compound 3; then compound 1.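

For the compounds shown here, this pair differs in one place only, so it gives the first direct reading of the change from 4-chlorophenyl to phenyl in this assay: removing the chloro produces a 2.7-fold higher number from compound 2 to compound 3 (0.42 log units; beyond the scatter). The step is modest but lies beyond the scatter, which shows that a single chlorine at this spot, para to a large group, has a measurable effect on the number here. No data at hand explain why the number moves in this direction.

From the compounds shown here alone, whether a fluoro, a methoxy or an amino group in the same place would land closer to compound 2 or to compound 3 remains open. Going by these compounds, it is also open whether removing the chloro would produce a similar step with a longer chain on the amine side of the molecule.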